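The source may hold more compounds than are shown below. What is called first, only, known or untested is meant among the compounds shown, and "the series" means these compounds.

Measured so far:
compound 1 `COc1cc(C2CC(c3ccc(OCc4cn(Cc5ccc([N+](=O)[O-])cc5)nn4)cc3)=NN2C(C)=O)ccc1Oc1cn(Cc2ccc([N+](=O)[O-])cc2)nn1` — 0%
compound 2 `COc1cc(C2CC(c3cc(OC)c(OC)c(OC)c3)=NN2C(C)=O)ccc1OCc1cn(Cc2ccc([N+](=O)[O-])cc2)nn1` — 29%
compound 3 `COc1ccc(C2CC(c3ccc(OCc4cn(Cc5ccc([N+](=O)[O-])cc5)nn4)cc3)=NN2C(C)=O)cc1OC` — 8%

In a functional assay on THP-1 cells (Homo sapiens) for inhibition, read by sulforhodamine B assay, tested at 10 uM (a higher number here means more inhibition of growth at the concentration tested, a lower number less inhibition of growth), compound 2 gives the highest of the three numbers. Compound 3 sits a number below it that is beyond the scatter, and compound 1 sits lower still, also beyond the scatter. Compound 4 `COc1cc(C2CC(c3ccc(Cl)cc3)=NN2C(C)=O)ccc1OCc1cn(Cc2ccc([N+](=O)[O-])cc2)nn1` has not been measured. It differs from compound 2 by 4-chlorophenyl in place of 3,4,5-trimethoxyphenyl on a carbon with a double bond to nitrogen. Going by the values given here, no direct step of this kind is available among the measured compounds, so the expectation rests only on the standing of compound 2. A moderate drop in this assay is expected, of the size a number 14 percentage points lower from compound 2 to compound 4 (beyond the scatter), though a change within the scatter cannot be excluded. Compound 4 is estimated at 15%, within a range from 0% to 35%.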

Compound 4, percent growth inhibition at one concentration: 17%
Compound 4: the middle estimate sits 2 percentage points below what was measured, within the range that was stated.
By their numbers in this assay, from the lowest: compounds 1, 3 and 4 (each within the scatter of the next, the first and the last beyond it); then compound 2.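

In this assay, the group on the carbon with a double bond to nitrogen now has a direct comparison: 4-chlorophenyl in place of 3,4,5-trimethoxyphenyl gives a number 12 percentage points lower from compound 2 to compound 4 (beyond the scatter). The position therefore bears on growth inhibition at the concentration tested, and within this pair the 3,4,5-trimethoxyphenyl compound stands higher. No measurement at hand accounts for the step. This single pair cannot separate the loss of the methoxy groups from the entry of chlorine. Going by these compounds, how a plain phenyl or an aminophenyl would stand at this position remains open.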